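Triazole aryl swap in the spirooxindole series

The source may report more compounds than this note shows. Statements on the series, on what has been measured and on what is new or still open speak of the compounds shown alone.

Going by the values given here, compound 2 `N#CC1=C(N)Oc2c(N)cc3nc4ccccc4nc3c2C12C(=O)N(Cc1cnnn1-c1cccc(Br)c1)c1ccccc12` gives 26100 nM in a functional assay on HCT-116 cells (Homo sapiens) for antiproliferative activity, read by MTT assay, with a stated time of 48 h (a lower number here means a stronger inhibitor, a higher number a weaker inhibitor), the only numerical reading in the set. For compound 1 `Cc1ccccc1-n1nncc1CN1C(=O)C2(C(C#N)=C(N)Oc3c(N)cc4nc5ccccc5nc4c32)c2ccccc21` the reading is a limit of the assay, > 50000 nM (the limit of > 50000 nM in this assay, at which 1 of the 2 values shown sits). The step of an at least 1.9-fold lower number from compound 1 to compound 2 (0.28 log units; that floor lies within the scatter) swapped the aryl on an aromatic nitrogen. Compound 3 `COc1ccccc1-n1nncc1CN1C(=O)C2(C(C#N)=C(N)Oc3c(N)cc4nc5ccccc5nc4c32)c2ccccc21` differs from compound 2 in the same place: 2-methoxyphenyl in place of 3-bromophenyl on an aromatic nitrogen. Among the compounds with values here, the one measured step in this assay sits at its floor within the scatter, so the expected step is a 1.3-fold higher number from compound 2 to compound 3 (0.13 log units; within the scatter), nothing beyond the scatter. Compound 3 is expected at 35000 nM, ranging from 12000 nM to 100000 nM.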

Compound 3, half-maximal inhibitory concentration: > 50000 nM
Compound 3: only a limit was reported (the forecaster's own chance of this, stated with the estimate: 40%); middle value at least 1.4-fold (0.15 log units) away from the limit.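

In this assay, 2-methoxyphenyl in place of 3-bromophenyl on the aromatic nitrogen gives an at least 1.9-fold higher number from compound 2 to compound 3 (0.28 log units; that floor lies within the scatter), so this second swap at the position also stays within the scatter at its floor. Compound 3 gives a limit and not a number, and this position now yields more limits than readings: the limit of > 50000 nM in this assay, at which 2 of the 3 values shown sit. Methoxy in place of methyl cannot be read, as both values are limits.

Still open, as far as these compounds go, is how far the true values lie from compound 2. From the compounds shown here alone, it is also open whether an amine or a carboxylic acid on this phenyl ring would give a reading.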